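This account rests on a few compounds, and the source may have more. Where it says the series, first, only, none or still open, it means among the compounds named here.

Compound 2 `O=C(/C=C\Nc1ccc(F)cc1)c1cn(-c2ccccc2)nc1-c1ccc(Cl)cc1` is one of two compounds with a result in a functional assay on PC-3 cells (Homo sapiens) for antiproliferative activity, read by MTT assay, with a stated time of 48 h; on this read-out higher numbers stand for weaker inhibition and lower numbers for stronger inhibition. In this assay compound 2 gives > 50000 nM, which is a limit of the assay rather than a number. For the measured compounds named here, compound 1 `O=C(/C=C\Nc1ccc(F)cc1)c1cn(-c2ccccc2)nc1-c1ccc(F)cc1`, the only measured comparison, gives 7900 nM, and the step of an at least 6.3-fold higher number from compound 1 to compound 2 (0.80 log units; beyond the scatter) rests on (the limit of > 50000 nM in this assay, at which 1 of the 2 values shown sits). Compound 3 `COc1ccc(N/C=C\C(=O)c2cn(-c3ccccc3)nc2-c2ccc(Cl)cc2)cc1` differs from compound 2 by methoxy in place of fluoro on an aromatic carbon. Going by the values given here, no measured step exchanges fluoro for methoxy, so the sole guide is that compound 2 already sits at the limit. Compound 3 is therefore expected to remain near that limit, an at least 1.2-fold lower number from compound 2 to compound 3 (0.09 log units; that floor lies within the scatter), with an estimate of 40000 nM ranging from 10000 nM to 100000 nM.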

Compound 3, half-maximal inhibitory concentration: 10700 nM
The estimate for compound 3 lay 3.7-fold (0.57 log units) above the measured number; low and high end bracket the measured number.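

In this assay, exchanging 4-fluorophenyl for 4-methoxyphenyl on the amino end gives an at least 4.6-fold lower number from compound 2 to compound 3 (0.66 log units; beyond the scatter). For the compounds shown here, with the chloro in place, this position, para to a large group, can therefore carry a change that moves the result off the limit, something the earlier compounds did not show. The size of this step is only a floor: the limit of > 50000 nM in this assay, at which 1 of the 3 values shown sits.

From the compounds shown here alone, it remains open whether the same exchange gives a like step with fluoro in place of that chloro, as in compound 1. Going by these compounds, it is also open what an amine, a hydroxyl or a longer ethoxy chain would give at this position.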